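Anilide variation on the shared core: paw edema inhibition notes

The compounds below may be only part of what the source reports. "The series", "measured", "known", "first", "only" and "open" are said of these compounds alone.

Measured so far:
compound 1 `O=C(NC1CCN(Cc2ccccc2)CC1)c1c(O)c2cccnc2n(-c2ccccc2)c1=O` — 1.2%
compound 2 `Cc1ccc(NC(=O)c2c(O)c3cccnc3n(-c3ccccc3)c2=O)cc1` — 2.2%
compound 3 `O=C(Nc1cccc(Cl)c1)c1c(O)c2cccnc2n(-c2ccccc2)c1=O` — 13.4%

In a functional assay on the whole organism for inhibition, with Rattus norvegicus as the target, read by cytopathic effect and paw edema, at a dose of 100 mg/kg by the oral route (on this read-out lower numbers stand for less inhibition and higher numbers for more inhibition at the one dose given (going by the name of the read-out)), compound 2 stands second highest of the three numbers. Its nearest neighbour is compound 1, whose value lies within the scatter of that of compound 2, so no order between the two is claimed. Going by the values given here, the only step beyond the scatter is a number 11.2 percentage points higher from compound 2 to compound 3 (beyond the scatter), a modest gain on exchanging the aryl group on the amide-type nitrogen.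

Compound 4 `COc1ccccc1NC(=O)c1c(O)c2cccnc2n(-c2ccccc2)c1=O` has not yet been measured. Its difference from compound 2 is 2-methoxyphenyl in place of 4-methylphenyl on an amide-type nitrogen. Among the compounds with values here, no measured pair shows this particular exchange; the step from compound 2 to compound 3 bears on it only in showing that an exchange of the aryl group at this position can shift the number modestly, in either direction for all that is known. On that basis the step of a number 2.8 percentage points higher from compound 2 to compound 4 (within the scatter) is expected to stay within the scatter, with a slight lean upward. Compound 4 is estimated at 5% in this assay, within a range from 0% to 15%.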

Compound 4, a percentage reported as inhibition, in the whole organism at one dose (the size of the read-out at that dose, not a potency): -10.1%
The estimate for compound 4 lay 15.1 percentage points above the measured number; the measured number lies below the stated range.
By their numbers in this assay, from the lowest: compound 4; then compounds 1 and 2 (each within the scatter of the next); then compound 3.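

In this assay the aryl group on the amide-type nitrogen can move the number down as well as up: 2-methoxyphenyl gives a number 12.3 percentage points lower from compound 2 to compound 4 (beyond the scatter) and also a number 23.5 percentage points lower from compound 3 to compound 4 (beyond the scatter) in this comparison. Going by these compounds alone, compound 4 gives -10.1% and so falls on the negative side of zero, which no earlier compound did, and this position is therefore not indifferent to the aryl group in either direction. No measurement at hand accounts for the drop or ties it to the methoxy group itself.

The compounds shown leave open whether the drop follows the methoxy group or the whole 2-methoxyphenyl group. A plain phenyl, or a phenyl carrying an amine or a carboxylic acid, would show how far this aryl position reaches beyond the three aryl groups in hand.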